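The compounds below may be only part of what the source reports. "The series", "measured", "known", "first", "only" and "open" are said of these compounds alone.

Going by the values given here, in a functional assay on PC-3 cells (Homo sapiens) for inhibition, read by MTT assay, with a stated time of 48 h (a higher number here means a weaker inhibitor, a lower number a stronger inhibitor), compound 1 `C=C1CC[C@@H]2[C@](C)(CO)[C@H](O)CC[C@@]2(C)[C@@H]1CC(Sc1ccc(C)cc1)C1=CCOC1=O` gives 29000 nM, the highest of the two numbers so far. Its nearest neighbour is compound 2 `C=C1CC[C@@H]2[C@](C)(CO)[C@H](O)CC[C@@]2(C)[C@@H]1CC(Sc1ccccc1)C1=CCOC1=O`, which in this assay gives 14000 nM. Among the compounds with values here, the one measured step, a 2.1-fold lower number from compound 1 to compound 2 (0.32 log units; beyond the scatter), comes from hydrogen in place of methyl on an aromatic carbon of the arylsulfanyl group. Compound 3 `C=C1CC[C@@H]2[C@](C)(CO)[C@H](O)CC[C@@]2(C)[C@@H]1CC(Sc1ccc([N+](=O)[O-])cc1)C1=CCOC1=O` alters the same aromatic carbon in a different way: nitro in place of methyl on an aromatic carbon. Within the data shown here, no measured step covers a nitro group, so the only guide is that the single change made at this aromatic carbon moved this assay by a modest amount towards a lower number. A step of similar size is therefore expected, with wide uncertainty, and the estimate for compound 3 in this assay is 15000 nM, within 5000 nM to 45000 nM, which would mean a 1.9-fold lower number from compound 1 to compound 3 (0.29 log units; within the scatter).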

Compound 3, half-maximal inhibitory concentration: 17000 nM
For compound 3 the middle estimate is 1.1-fold (0.05 log units) below the measured one, and the stated range covers the measured number.
By their numbers in this assay, from the lowest: compounds 2, 3 and 1 (each within the scatter of the next, the first and the last beyond it).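

In this assay nitro on this aromatic carbon cannot be separated from either neighbour, with a 1.7-fold lower number from compound 1 to compound 3 (0.23 log units; within the scatter) and a 1.2-fold higher number from compound 2 to compound 3 (0.08 log units; within the scatter) both inside the scatter. Methyl, hydrogen and nitro at this carbon therefore span a narrow band, and the only pair beyond the scatter is compound 1 and compound 2, so entry of the three heavy atoms of nitro in place of methyl brings no separable change on its own. Nothing available explains where compound 3 falls in this band.

The compounds shown leave open whether an amine or a carboxylic acid on this aromatic carbon would stay within the same band. They also leave open how far the numbers would move with a change to the sulfanyl link or to the shared core rather than to this carbon.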